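Chain Extension Repeated on a Second Core

The compounds below may be only part of what the source reports. "The series", "measured", "known", "first", "only" and "open" are said of these compounds alone.

Three compounds have been measured in a functional assay on NCI-H460 cells (Homo sapiens) for antiproliferative activity, read by MTT assay, with a stated time of 48 h; a lower number here means a stronger inhibitor, a higher number a weaker inhibitor:

Compound 1, `O=C(CSc1nnc(NC(=O)CCl)s1)Nc1ccc(Cl)cn1`: 5700 nM
Compound 2, `O=C(CSc1nnc(NC(=O)CCCCl)s1)Nc1ccc(Cl)cn1`: 55200 nM
Compound 3, `O=C(CCl)Nc1ccc(SCC(=O)Nc2ccc(Cl)cn2)cc1`: 420 nM

Compound 1 and compound 2 share one core, while compound 3 is built on another; the difference between the two cores is not broken down here. On the first core, the change 2-chloroethyl in place of chloro on a saturated chain carbon bound to a carbonyl carbon produced a 9.7-fold higher number from compound 1 to compound 2 (0.99 log units; beyond the scatter) in this assay. Compound 4, `O=C(CCCCl)Nc1ccc(SCC(=O)Nc2ccc(Cl)cn2)cc1`, has not yet been measured. It carries the same change relative to compound 3, (2-chloroethyl in place of chloro on a saturated chain carbon bound to a carbonyl carbon), at the same place. Compound 3 holds the lowest of the three numbers in this assay. The expectation for compound 4 rests on that single earlier step, a 9.7-fold higher number from compound 1 to compound 2 (0.99 log units; beyond the scatter), being carried over. Compound 4 is therefore expected to show a 9.5-fold higher number from compound 3 to compound 4 (0.98 log units; beyond the scatter). Compound 4 is estimated at 4000 nM, with a range from 1300 nM to 12000 nM.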

Compound 4, half-maximal inhibitory concentration: > 80000 nM
Compound 4 gave a limit, no number (the forecaster's own chance of this, stated with the estimate: 5%); at least 20-fold (1.30 log units) between middle value and limit.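

In this assay, going by these compounds, replacing chloromethyl with 3-chloropropyl raised the number on both cores, so the direction of the change held, but its size did not carry over, with an at least 190-fold higher number from compound 3 to compound 4 (2.27 log units; beyond the scatter) set against the earlier step: the same change on two cores in this assay, a 9.7-fold higher number (0.99 log units; beyond the scatter) from compound 1 to compound 2 and an at least 190-fold higher number (2.27 log units; beyond the scatter) from compound 3 to compound 4, at least 19-fold (1.29 log units) apart, beyond the scatter of two such steps The value of compound 4, > 80000 nM, is a limit of the assay and not a number, so the full size of its step remains unknown. One step on each core does not show why the two differ, nor what the change would do on any further core.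

The compounds shown leave open how a bromomethyl group or a plain propyl chain would read at the same place on either core.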